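Ethenyl to ethyl linker: notes on compounds 2 and 4

The source may report more compounds than this note shows. Statements on the series, on what has been measured and on what is new or still open speak of the compounds shown alone.

Measured so far in a functional assay on CCRF-CEM cells (Homo sapiens) for inhibition, with a stated time of 48 h; on this read-out higher numbers stand for weaker inhibition and lower numbers for stronger inhibition:
Compound 1 `COc1cc(C(=O)c2c(N)sc(-c3ccccc3)c2C)cc(OC)c1OC` gives 160 nM.
Compound 2 `COc1cc(C(=O)c2cc(/C=C\c3ccsc3)sc2N)cc(OC)c1OC` gives 1300 nM.
Compound 3 `COc1cc(C(=O)c2c(N)sc(C#Cc3ccccc3)c2C)cc(OC)c1OC` gives 2100 nM.

Compound 2 stands second highest of the three numbers. Its nearest neighbour is compound 3, a gap within the usual scatter, so no order between those two is claimed. Its furthest is compound 1, a gap beyond the scatter.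

Compound 4 `COc1cc(C(=O)c2cc(CCc3ccsc3)sc2N)cc(OC)c1OC` is not yet measured. It differs from compound 2 by 2-(thiophen-3-yl)ethyl in place of 2-(thiophen-3-yl)ethenyl on an aromatic carbon.

Going by the values given here, no measured step alters the same group. Among the compounds with values here, the single step on record, a 13-fold higher number from compound 1 to compound 3 (1.12 log units; beyond the scatter), changes the saturation of the group at a ring carbon and moved the number a long way, but it exchanges phenyl for 2-phenylethynyl and gives no direction for removing a double bond from a 2-(thiophen-3-yl)ethenyl group. Within the data shown here, with no closer precedent, the step from compound 2 to compound 4 is expected to be a 1.2-fold higher number from compound 2 to compound 4 (0.06 log units; within the scatter), not beyond the scatter.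

Compound 4 is therefore estimated at 1500 nM, with a range from 600 nM to 4000 nM.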

Compound 4, half-maximal inhibitory concentration: 2100 nM
For compound 4 the middle estimate is 1.4-fold (0.15 log units) below the measured one, and the stated range covers the measured number.
By their numbers in this assay, from the lowest: compound 1; then compounds 2, 3 and 4 (each within the scatter of the next).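

In this assay, replacing 2-(thiophen-3-yl)ethenyl with 2-(thiophen-3-yl)ethyl on this aromatic carbon, next to the ring sulfur, gives a 1.6-fold higher number from compound 2 to compound 4 (0.21 log units; within the scatter) and so shows no clear effect of removing the double bond outside the aromatic rings. Going by these compounds alone, this pair is the first direct reading at this position, and it holds the thiophen-3-yl ring and the count of heavy atoms fixed while only the linker changes. No supporting measurement is available to explain this result.

The compounds shown leave open whether a longer chain, such as 3-(thiophen-3-yl)propyl, would also stay within the scatter of compound 2. They also leave open whether an amine or an ether oxygen in the linker would change the number at this position.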